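The compounds below may be only part of what the source reports. "The series", "measured", "known", "first", "only" and "open" are said of these compounds alone.

Compound 1 `Cc1ccc(C(=O)OC2(C(=O)Nc3ccc([N+](=O)[O-])cc3)CCCCC2)cc1` belongs to a small set of esters built on a shared core. In a functional assay on HepG2 cells (Homo sapiens) for inhibition, read by MTT assay, with a stated time of 72 h (a higher number here means a weaker inhibitor, a lower number a stronger inhibitor), compound 1 gives 61.2 nM. Its closest neighbour is compound 2 `COc1ccc(C(=O)OC2(C(=O)Nc3ccc([N+](=O)[O-])cc3)CCCCC2)cc1`, which gives 57.1 nM; the change from one to the other is a 1.1-fold lower number from compound 1 to compound 2 (0.03 log units; within the scatter). The third member, compound 3 `O=C(OC1(C(=O)Nc2ccc([N+](=O)[O-])cc2)CCCCC1)c1ccc(Br)cc1`, gives 284 nM, and the steps to it are a 4.6-fold higher number from compound 1 to compound 3 (0.67 log units; beyond the scatter) and a 5.0-fold higher number from compound 2 to compound 3 (0.70 log units; beyond the scatter). Compound 1 therefore stands second highest of the three numbers, close to compound 2 and well apart from compound 3.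

Compound 4 `CC(=O)OC1(C(=O)Nc2ccc([N+](=O)[O-])cc2)CCCCC1` has not yet been measured. It differs from compound 1 by methyl in place of 4-methylphenyl on a carbonyl carbon. For the measured compounds named here, none of the measured steps touches this change: all three measured compounds keep the 4-substituted phenyl ring and vary only the group on it, whereas compound 4 removes the ring entirely and leaves an acetyl. The measured steps show that swapping methyl for methoxy does nothing beyond the scatter, while bromo weakens inhibition modestly, but they say nothing about dropping the aromatic ring. Given that, the expected step in this assay is uncertain in direction, with a modest weakening the more likely outcome, about a 3.3-fold higher number from compound 1 to compound 4 (0.51 log units; beyond the scatter). Compound 4 is estimated at 200 nM, within a range from 40 nM to 1000 nM.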

Compound 4, half-maximal inhibitory concentration: 519 nM
Estimate against measurement, compound 4: 2.6-fold (0.41 log units) below; the measured number falls inside the stated range.
By their numbers in this assay, from the lowest: compounds 2 and 1 (each within the scatter of the next); then compounds 3 and 4 (each within the scatter of the next).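

Swapping the aromatic ring on this carbonyl carbon for a methyl is a far larger kind of change than the earlier swaps on the ring, and in this assay its outcome depends on which ring leaves: removing 4-methylphenyl gives an 8.5-fold higher number from compound 1 to compound 4 (0.93 log units; beyond the scatter) and removing 4-methoxyphenyl gives a 9.1-fold higher number from compound 2 to compound 4 (0.96 log units; beyond the scatter) as the result, both beyond the usual scatter. The 4-bromophenyl ester goes against any simple rule that the ring alone keeps the number low, since its replacement gives a 1.8-fold higher number from compound 3 to compound 4 (0.26 log units; within the scatter) and so makes no clear difference. Among these four compounds, then, the lower numbers belong only to the rings carrying methyl or methoxy, and nothing available explains why the bromo ring behaves like the acetyl.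

What the compounds shown leave open is how a plain phenyl with nothing on it, a benzyl group or a longer chain such as butyl would read on this carbonyl carbon. They also leave open how an amine or a carboxylic acid on the ring would compare with methyl, methoxy and bromo.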